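A few compounds are considered here, and "the series" means these few. Any claim that something is new, unique, unknown or untested is made for them only; others in the source may bear on it.

Working notes on the shared core, a fused two-ring system carrying a phenyl group and a variable substituent.

Compound 3, `Nc1cc(N)c2nc(-c3ccccc3)c(Sc3ccc(Cl)c(Cl)c3)nc2c1`, is measured in a functional assay on M14 cells (Homo sapiens) for inhibition, read by sulforhodamine B assay, with a stated time of 48 h; on this read-out higher numbers stand for lower toxicity in this test and lower numbers for higher toxicity in this test. In this assay compound 3 gives only a limit, < 100000 nM. Compound 1, `Nc1cc(N)c2nc(-c3ccccc3)c(NCc3ccc(F)cc3)nc2c1`, in this assay also gives a limit, < 100000 nM. Compound 2, `COc1ccc(Sc2nc3cc(N)cc(N)c3nc2-c2ccccc2)cc1`, in this assay gives a limit as well, < 100000 nM. All three readings sit at the limit of < 100000 nM in this assay, at which 3 of the 3 values shown sit, so compound 3 stands level with the others as far as the numbers show. The step that the two limits leave unreadable from compound 1 to compound 2 cannot be read, nor can a step that the two limits leave unreadable from compound 1 to compound 3 or a step that the two limits leave unreadable from compound 2 to compound 3.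

Compound 4, `Nc1cc(N)c2nc(-c3ccccc3)c(Oc3ccc(F)cc3)nc2c1`, is not yet measured in this assay. It differs from compound 3 by 4-fluorophenoxy in place of (3,4-dichlorophenyl)sulfanyl on an aromatic carbon. The measured steps that bear on this change are those exchanging the group on the same aromatic carbon, a step that the two limits leave unreadable from compound 1 to compound 3 and a step that the two limits leave unreadable from compound 2 to compound 3, and both are unreadable. Nothing measured therefore gives a direction or a size. The step that the limit leaves unreadable from compound 3 to compound 4 is expected to be none beyond the scatter, with the reading most likely again a limit. Compound 4 is estimated at 30000 nM, within 5000 nM to 100000 nM.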

Compound 4, concentration lethal to 50% of the cells: < 100000 nM
Compound 4: no number, only a limit; the forecaster's own chance of this, stated with the estimate: 70%; the middle value lies beyond the limit too.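

In this assay compound 4 gives only a limit, < 100000 nM. Going by these compounds alone, no step from compound 1, compound 2 or compound 3 to compound 4 can be read, and all the readings are limits: the limit of < 100000 nM in this assay, at which 4 of the 4 values shown sit. The compounds shown leave open whether exchanging the group on this aromatic carbon changes the reading in this assay at all, and in which direction.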